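A few compounds are considered here, and "the series" means these few. Any claim that something is new, unique, unknown or untested is made for them only; others in the source may bear on it.

Measured so far in a functional assay on the whole organism (strain albino) for inhibition, with Rattus norvegicus as the target, read by paw edema, with stated times of 30 min and 4 h, at a dose of 0.28 mmol/kg by the oral route; a lower number here means less inhibition, a higher number more inhibition at the dose given (going by the name of the read-out):
compound 1, `COc1ccc(-c2nnc(SCC(=O)Nc3ccc(/C(C)=N/O)cc3)n2-c2ccccc2)cc1`, 69%;
compound 2, `CCn1c(SCC(=O)Nc2ccc(/C(C)=N/O)cc2)nnc1-c1ccc(OC)cc1`, 73%;
compound 3, `C=CCn1c(SCC(=O)Nc2ccc(/C(C)=N/O)cc2)nnc1-c1ccc(OC)c(OC)c1`, 79%.

Compound 3 gives the highest of the three numbers, but its lead over compound 2 and over compound 1 lies within the scatter, so the three cannot be ordered. Among the measured compounds shown here, the only step between two compounds that differ in one place is the one with ethyl in place of phenyl on an aromatic nitrogen, a number 4 percentage points higher from compound 1 to compound 2 (within the scatter), again within the scatter.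

Compound 4, `C=CCn1c(SCC(=O)Nc2ccc(/C(C)=N/O)cc2)nnc1-c1ccc(OC)cc1`, is to be measured. It differs from compound 3 as follows: hydrogen in place of methoxy on an aromatic carbon. For the measured compounds named here, no measured step in this assay involves a methoxy group, so the change has no direct precedent here. Going by the values given here, what can be said is that compound 2 also carries a 4-methoxyphenyl and gives 73%, a number close to that of compound 3; the one measured step, a number 4 percentage points higher from compound 1 to compound 2 (within the scatter), shows that a change elsewhere on the shared core moved the inhibition little.

On this basis the expected step from compound 3 to compound 4 is small: a number 6 percentage points lower from compound 3 to compound 4 (within the scatter), not beyond the scatter in either direction. The estimate for compound 4 in this assay is 73%, with a range of 60% to 84%.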

Compound 4, a percentage reported as inhibition, in the whole organism at one dose (the size of the read-out at that dose, not a potency): 75%
The estimate for compound 4 lay 2 percentage points below the measured number, within the range that was stated.
By their numbers in this assay, from the lowest: compounds 1, 2, 4 and 3 (each within the scatter of the next).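

In this assay, among the compounds shown here, the change from 3,4-dimethoxyphenyl to 4-methoxyphenyl gives a number 4 percentage points lower from compound 3 to compound 4 (within the scatter), so this is the first reading at this aromatic carbon, and taking away the methoxy group there does not move the inhibition beyond the scatter at this one dose. With the 4-methoxyphenyl held fixed, the group on the aromatic nitrogen adds two more readings that stay inside the scatter: vinyl in place of methyl on the saturated chain carbon gives a number 2 percentage points higher from compound 2 to compound 4 (within the scatter), and allyl in place of phenyl gives a number 6 percentage points higher from compound 1 to compound 4 (within the scatter). No measurement on these compounds speaks to why these steps are this small.

A percentage at a single dose is not a potency, so these close numbers leave open whether the compounds would separate across a range of doses. As far as these compounds go, it also remains open whether a different group at this aromatic carbon, such as a hydroxyl, a chlorine atom or a carboxylic acid, or a longer chain on the aromatic nitrogen, would move the number beyond the scatter.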